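The source may hold more compounds than are shown below. What is called first, only, known or untested is meant among the compounds shown, and "the series" means these compounds.

Working notes on the series.

Compound 1 `CN(C)CCNc1nc(-c2ccc(NC(=O)Nc3ccc(F)cc3)cc2)nc2ccsc12` in a functional assay on MKN-45 cells (Homo sapiens) for cytotoxicity, read by MTT assay, with a stated time of 72 h (on this read-out higher numbers stand for weaker inhibition and lower numbers for stronger inhibition), gives 330 nM. Compound 2 `CN(C)CCNc1nc(-c2ccc(NC(=O)Nc3ccccc3F)cc2)nc2ccsc12` carries the change 2-fluorophenyl in place of 4-fluorophenyl on an amide-type nitrogen and in this assay gives 530 nM, a step of a 1.6-fold higher number from compound 1 to compound 2 (0.21 log units; within the scatter). Compound 3 `CCN(CC)CCCNc1nc(-c2ccc(NC(=O)Nc3ccc(F)cc3)cc2)nc2ccsc12` differs from compound 1 by (diethylamino)methyl in place of dimethylamino on a saturated chain carbon, two bonds along the chain from a nitrogen on an aromatic ring. In this assay compound 3 gives 470 nM, a step of a 1.4-fold higher number from compound 1 to compound 3 (0.15 log units; within the scatter). Compound 4 `CCN(CC)CCCNc1nc(-c2ccc(NC(=O)Nc3ccccc3F)cc2)nc2ccsc12` has not yet been measured in this assay; it differs from compound 3 by 2-fluorophenyl in place of 4-fluorophenyl on an amide-type nitrogen, which is the same change as that from compound 1 to compound 2, made on the core of compound 3 rather than on the core of compound 1. Among the measured compounds shown here, the expected step from compound 3 to compound 4 is a 1.5-fold higher number from compound 3 to compound 4 (0.19 log units; within the scatter), set beside a 1.6-fold higher number from compound 1 to compound 2 (0.21 log units; within the scatter) because a 1.6-fold higher number from compound 1 to compound 2 (0.21 log units; within the scatter) is the only time this change has been seen so far. For compound 4 the estimated value in this assay is 720 nM, with a range from 400 nM to 1300 nM.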

Compound 4, half-maximal inhibitory concentration: 580 nM
Estimate against measurement, compound 4: 1.2-fold (0.09 log units) above, within the range that was stated.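

The change to 2-fluorophenyl in place of 4-fluorophenyl gives a 1.2-fold higher number from compound 3 to compound 4 (0.09 log units; within the scatter) and matches its earlier appearance on the core of compound 1: the same change on two cores in this assay, a 1.6-fold higher number (0.21 log units; within the scatter) from compound 1 to compound 2 and a 1.2-fold higher number (0.09 log units; within the scatter) from compound 3 to compound 4, 1.3-fold (0.11 log units) apart, within the scatter of two such steps. The change to (diethylamino)methyl in place of dimethylamino gives a 1.1-fold higher number from compound 2 to compound 4 (0.04 log units; within the scatter) and likewise holds on both cores: the same change on two cores in this assay, a 1.4-fold higher number (0.15 log units; within the scatter) from compound 1 to compound 3 and a 1.1-fold higher number (0.04 log units; within the scatter) from compound 2 to compound 4, 1.3-fold (0.11 log units) apart, within the scatter of two such steps. Among the compounds shown here, all of these steps lie within the scatter in this assay and so show only that neither change has a measurable effect on these two cores, not that a step of real size would carry from one core to another.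

Still open, on these data alone, is how an unsubstituted phenyl or a chlorophenyl group on the amide-type nitrogen would compare. The same applies to a cyclic amine such as morpholine in place of dimethylamino.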